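A few compounds are considered here, and "the series" means these few. Any claim that something is new, unique, unknown or untested is made for them only; others in the source may bear on it.

Among the measured compounds shown here, compound 2 `COc1ccc(-c2cc(NC(=O)CCC(=O)N(C)CC(=O)NC3CCCCC3)nc(-c3ccc(OC)cc3)n2)cc1` gives 52900 nM in an assay on HeLa cells for displacement of a labelled ligand from adenosine receptor A3 (Homo sapiens), read by fluorescence polarization, with a stated time of 30 min (a lower number here means a stronger inhibitor, a higher number a weaker inhibitor), one of only two numbers measured; the other, for compound 1 `COc1ccc(-c2cc(NC(=O)CCC(=O)NCC(=O)NCc3ccccc3)nc(-c3ccc(OC)cc3)n2)cc1` at 50800 nM, lies within the scatter of it, the step being a 1.0-fold higher number from compound 1 to compound 2 (0.02 log units; within the scatter). Compound 3 `COc1ccc(-c2cc(NC(=O)CCC(=O)N(C)CC(=O)NCc3ccccc3)nc(-c3ccc(OC)cc3)n2)cc1` differs from compound 2 by benzyl in place of cyclohexyl on an amide-type nitrogen. For the measured compounds named here, only that earlier step bears on this change, and it stayed within the scatter, so no shift beyond the scatter in this assay is expected. The estimate for compound 3 is therefore 50000 nM, within 20000 nM to 130000 nM. The expected step is a 1.1-fold lower number from compound 2 to compound 3 (0.02 log units; within the scatter).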

Compound 3, inhibition constant: 35400 nM
Beside the measured number, compound 3's estimate is 1.4-fold (0.15 log units) above it; low and high end bracket the measured number.
By their numbers in this assay, from the lowest: compounds 3, 1 and 2 (each within the scatter of the next).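

In this assay, benzyl in place of cyclohexyl on the amide-type nitrogen alone gives a 1.5-fold lower number from compound 2 to compound 3 (0.17 log units; within the scatter), while methyl in place of hydrogen on an amide-type nitrogen alone gives a 1.4-fold lower number from compound 1 to compound 3 (0.16 log units; within the scatter). The two changes made together in the earlier step are thus separated, and each stays within the scatter on its own. No evidence on why these numbers stand as they do is available. On these data alone, whether an amine or a carboxylic acid on the benzyl group, or a longer chain in its place, would move the number beyond the scatter remains open.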